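The source may report more compounds than this note shows. Statements on the series, on what has been measured and on what is new or still open speak of the compounds shown alone.

Measured so far in an ADME assay on microsomes from liver (Homo sapiens) for metabolic stability, tested at 2.5 uM; on this read-out higher numbers stand for fast clearance and lower numbers for slow clearance:
compound 1 `O=S(=O)(c1ccc(F)c(Cl)c1)c1cnc2cc(F)ccc2c1-c1ccc(F)cc1` — 0.69 mL/min
compound 2 `O=S(=O)(c1ccc(F)c(Cl)c1)c1cnc2cc(F)ccc2c1-c1ccccc1F` — 1.07 mL/min

Of the two numbers shown, compound 2's is the larger, but a 1.6-fold higher number from compound 1 to compound 2 (0.19 log units; within the scatter) is within the scatter, so the two compounds are not separated in this assay. Compound 3 `O=S(=O)(c1ccc(F)c(Cl)c1)c1cnc2cc(F)ccc2c1-c1cccc(F)c1` is not yet measured; it differs from compound 2 as follows: 3-fluorophenyl in place of 2-fluorophenyl on an aromatic carbon. For the measured compounds named here, the only step that bears on this change is that from compound 1 to compound 2, a shift of fluorine within the same ring, and it stayed within the scatter. No step beyond the scatter is therefore expected: a 1.2-fold lower number from compound 2 to compound 3 (0.08 log units; within the scatter). Compound 3 is estimated at 0.9 mL/min, with a range of 0.45 mL/min to 1.8 mL/min.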

Compound 3, intrinsic clearance in a liver preparation (reported as CLH), per the amount of preparation that the assay uses: 0.25 mL/min
Estimate against measurement, compound 3: 3.6-fold (0.56 log units) above, outside the stated range (below it).
By their numbers in this assay, from the lowest: compound 3; then compounds 1 and 2 (each within the scatter of the next).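

In this assay the place of the fluorine on this phenyl ring now counts: 3-fluorophenyl gives a 4.3-fold lower number from compound 2 to compound 3 (0.63 log units; beyond the scatter) and a 2.8-fold lower number from compound 1 to compound 3 (0.44 log units; beyond the scatter) while 2-fluorophenyl and 4-fluorophenyl remain within the scatter of each other. A shift of fluorine at this place on the shared core can therefore move the read-out beyond the scatter, which the earlier pair did not show. Nothing measured here accounts for the difference.

Open, going by these compounds, is whether the lower number holds for chlorine or a methoxy group in place of the fluorine of 3-fluorophenyl. On these data alone, how an unsubstituted phenyl compares with these three compounds is also open.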